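The source may hold more compounds than are shown below. What is called first, only, known or untested is meant among the compounds shown, and "the series" means these compounds.

Compound 1 `C/C(=N\NC(=S)Nc1ccc(Cl)cc1)c1ccccn1`: 8.49 nM
Compound 2 `C/C(=N/NC(=S)Nc1ccccc1)c1ccccn1`: 0.18 nM
Compound 3 `C/C(=N/NC(=S)Nc1ccc(Cl)cc1)c1ccccn1`: 8.49 nM

All three values come from a functional assay on MCF7 cells (Homo sapiens) for cytotoxicity, read by MTT assay, with a stated time of 48 h; a lower number here means a stronger inhibitor, a higher number a weaker inhibitor. Compound 1 and compound 3 sit level, together the highest of the three numbers, and compound 2 lies well below them.

The next compound, compound 4 `C/C(=N/NC(=S)Nc1ccc([N+](=O)[O-])cc1)c1ccccn1`, has nitro in place of chloro on an aromatic carbon, para to a large group: nitro in place of chloro on an aromatic carbon.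

Two measured steps are available, and neither puts nitro on the ring. The step of no change at the digits printed from compound 1 to compound 3 (within the scatter) rests on (the fact that compounds 1 and 3 differ only in the configuration as drawn), so it says nothing about a new group. The step of a 47-fold higher number from compound 2 to compound 3 (1.67 log units; beyond the scatter) is large and shows that a single replacement on an aromatic carbon can move the number a long way. Among the measured compounds shown here, with only that one comparison, the direction remains open. A modest step is expected, with a slight lean toward lower numbers and a wide range. For compound 4 the estimate is 6 nM, expected to lie between 0.6 nM and 40 nM. This expectation amounts to a 1.4-fold lower number from compound 3 to compound 4 (0.15 log units; within the scatter).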

Compound 4, half-maximal inhibitory concentration: 52 nM
The estimate for compound 4 lay 8.7-fold (0.94 log units) below the measured number, and the stated range ends below it.
By their numbers in this assay, from the lowest: compound 2; then compounds 1 and 3 (each within the scatter of the next); then compound 4.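

Nitro in place of chloro gives a 6.1-fold higher number from compound 3 to compound 4 (0.79 log units; beyond the scatter), so this ring position has not reached its limit with chloro: a different group on the same aromatic carbon moves the number further up. Set against hydrogen, nitro gives a 290-fold higher number from compound 2 to compound 4 (2.46 log units; beyond the scatter), so both groups shown on this carbon make a weaker inhibitor than hydrogen does, and nitro makes a weaker one than chloro. Nothing measured here explains why nitro and chloro differ.

On these data alone, only hydrogen, chloro and nitro appear on this carbon, so it remains open whether a methoxy group or an amine there would keep the number as low as hydrogen does. As far as these compounds go, it is also open whether the nitro compound, like the chloro pair, would give the same number with its double bond drawn the other way.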